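A Benzyl Group on an Aromatic Nitrogen, Tried Again

A few compounds are considered here, and "the series" means these few. Any claim that something is new, unique, unknown or untested is made for them only; others in the source may bear on it.

Measured compounds:
Compound 1, `CC(C)(C)OC(=O)N1CCN(C(=O)CCCc2c[nH]c3ccccc23)CC1`: 84.1%
Compound 2, `COc1ccc2[nH]c(C)c(CCCC(=O)N3CCN(C(=O)OC(C)(C)C)CC3)c2c1`: 71.2%
Compound 3, `CC(C)(C)OC(=O)N1CCN(C(=O)CCCc2cn(Cc3ccccc3)c3ccccc23)CC1`: 38.2%

All three compounds were tested in an assay on cells for inhibition of Polyunsaturated fatty acid 5-lipoxygenase (Rattus norvegicus), tested at 5 uM; a higher number here means more inhibition at the concentration tested (going by the name of the read-out), a lower number less inhibition. In this assay compound 1 gives 84.1%, compound 2 gives 71.2%, and compound 3 gives 38.2%. Compound 3 differs from compound 1 in a single place, (benzyl in place of hydrogen on an aromatic nitrogen), and this change produced a number 45.9 percentage points lower from compound 1 to compound 3 (beyond the scatter). The core of compound 2 differs from the core of compound 1 in more than one place; the difference between the two cores is not broken down here.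

Compound 4, `COc1ccc2c(c1)c(CCCC(=O)N1CCN(C(=O)OC(C)(C)C)CC1)c(C)n2Cc1ccccc1`, has not yet been measured. It differs from compound 2 by benzyl in place of hydrogen on an aromatic nitrogen. Going by the values given here, this is the same kind of change as the one from compound 1 to compound 3, but not the same: in compound 4 the aromatic nitrogen that receives the benzyl group sits next to the ring atom that bears a methyl group, whereas in compound 3 no such neighbouring methyl group is present.

Since the earlier change gave a number 45.9 percentage points lower from compound 1 to compound 3 (beyond the scatter), a large drop of similar size is expected from compound 2 to compound 4, namely a number 41.2 percentage points lower from compound 2 to compound 4 (beyond the scatter). Among the compounds with values here, this expectation rests on compound 2 starting at 71.2% and on the single earlier example; whether the neighbouring methyl group alters the outcome cannot be judged from these data. Compound 4 is therefore estimated to give 30%, expected to fall between 10% and 52%.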

Compound 4, a percentage reported as inhibition, at one concentration (the size of the read-out at that concentration, not a potency): 51.5%
Beside the measured number, compound 4's estimate is 21.5 percentage points below it; low and high end bracket the measured number.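

In this assay, the benzyl group on the aromatic nitrogen lowers the number on the second core as well, with a number 19.7 percentage points lower from compound 2 to compound 4 (beyond the scatter). The direction of the change therefore carries over from one core to the other, but its size does not, as the two steps set side by side show: the same change on two cores in this assay, a number 45.9 percentage points lower (beyond the scatter) from compound 1 to compound 3 and a number 19.7 percentage points lower (beyond the scatter) from compound 2 to compound 4, 26.2 percentage points apart, beyond the scatter of two such steps. Going by these compounds alone, this shows that the drop seen on one core cannot simply be subtracted from a compound on another core, yet it does not show which feature of the cores sets the size of the drop, since the two cores differ in more than one place and only two pairs are available.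

On these data alone, it remains open how a core carrying only the methyl group, or only the methoxy group, would respond to the same benzyl group, which would help separate the part each plays in the smaller step. As far as these compounds go, it is also open whether a different group on that aromatic nitrogen, such as a methyl group, a longer chain ending in a phenyl ring or a chain ending in a carboxylic acid, would lower the inhibition as much as benzyl does.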